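The compounds below may be only part of what the source reports. "The series", "measured", "known", "first", "only" and "open" are said of these compounds alone.

Compound 1 `COc1ccccc1-c1nc2ncccc2o1`: 9%
Compound 2 `N#Cc1ccccc1-c1nc2ncccc2o1`: 62%

In a functional assay on the whole organism for inhibition, with Rattus norvegicus as the target, at a dose of 30 mg/kg (a higher number here means more inhibition at the dose given (going by the name of the read-out), a lower number less inhibition), compound 1 gives 9%, while compound 2 gives 62%. Among the measured compounds shown here, the only measured step is a number 53 percentage points higher from compound 1 to compound 2 (beyond the scatter), so compound 2 stands highest of the two numbers, with compound 1 as its sole neighbour, lower by that step and beyond the scatter.

Compound 3 `Brc1ccccc1-c1nc2ncccc2o1` has not yet been measured. It differs from compound 2 in one place: bromo in place of cyano on an aromatic carbon. For the measured compounds named here, no measured step sets bromo against cyano. Going by the values given here, the one step that exists, a number 53 percentage points higher from compound 1 to compound 2 (beyond the scatter), shows that exchanging the group on this aromatic carbon can shift the read-out by a large amount, but it gives no direction for the present exchange, since methoxy, not bromo, stood there before. Among the compounds with values here, with compound 2 as the starting point and only this indirect precedent, a drop of moderate size is expected, a number 22 percentage points lower from compound 2 to compound 3 (beyond the scatter), carrying a wide uncertainty. Compound 3 is therefore estimated to give 40%, with a range from 15% to 65%.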

Compound 3, a percentage reported as inhibition, in the whole organism at one dose (the size of the read-out at that dose, not a potency): 24%
The estimate for compound 3 lay 16 percentage points above the measured number; measured number inside the range.
By their numbers in this assay, from the lowest: compound 1; then compound 3; then compound 2.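

In this assay, a third group now sits on the same aromatic carbon of the shared core, and the exchange of cyano for bromo gives a number 38 percentage points lower from compound 2 to compound 3 (beyond the scatter), so cyano now stands ahead of two different groups at this place rather than one. Bromo is also separable from methoxy here, with a number 15 percentage points higher from compound 1 to compound 3 (beyond the scatter), which places the three groups in the order methoxy, bromo, cyano from the lowest number to the highest, each gap lying beyond the scatter and the step from methoxy to bromo being much the smaller of the steps up to cyano's level. No evidence is available that would account for this order or for the size of these steps.

Three groups on one carbon cannot show whether the order would extend to others, such as a chlorine, a methyl, an amine or a carboxylic acid, or whether any of them would match cyano at this place. On these data alone, whether cyano would keep its lead on another carbon of the same ring, or at another dose, also remains open.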